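The source may hold more compounds than are shown below. What is called first, only, known or untested is meant among the compounds shown, and "the series" means these compounds.

Values so far in a functional assay on NCI-H1975 cells (Homo sapiens) for cytotoxicity, read by MTT assay, with a stated time of 72 h; a lower number here means a stronger inhibitor, a higher number a weaker inhibitor:
- compound 1 `N#Cc1ccc(/C=N/NC(=O)N2CCc3ncnc(Nc4ccc(F)c(Cl)c4)c3C2)cc1` gives 67500 nM
- compound 2 `O=C(N/N=C/c1cccs1)N1CCc2ncnc(Nc3ccc(F)c(Cl)c3)c2C1` gives 33000 nM
- compound 3 `O=C(N/N=C/c1ccc(F)cc1Cl)N1CCc2ncnc(Nc3cccc(Br)c3)c2C1` gives 15700 nM

Compound 3 has the lowest number of the three. Compound 2 and compound 1 both lie higher, and both gaps are beyond the scatter. Compound 4 `O=C(N/N=C/c1cccnc1)N1CCc2ncnc(Nc3cccc(Br)c3)c2C1` is not yet measured. It differs from compound 3 in one group: pyridin-3-yl in place of 2-chloro-4-fluorophenyl on a carbon with a double bond to nitrogen.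

Within the data shown here, the only measured step at this place is a 2.0-fold lower number from compound 1 to compound 2 (0.31 log units; beyond the scatter), with thiophen-2-yl in place of 4-cyanophenyl. It is modest and beyond the scatter. Among the measured compounds shown here, neither of its groups is involved in the present change, and no measured step starts from compound 3, so it indicates a size and not a direction.

A step of similar modest size is therefore expected in this assay. The expected direction leans upward, since compound 3 at 15700 nM is the lowest of the three values, though this lean is weak. The estimate amounts to an expected 1.7-fold higher number from compound 3 to compound 4 (0.24 log units; within the scatter). For compound 4 the expected value is 27000 nM, with an estimated range from 10000 nM to 65000 nM.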

Compound 4, half-maximal inhibitory concentration: > 200000 nM
Compound 4: no number, only a limit (the forecaster's own chance of this, stated with the estimate: 8%); middle value at least 7.4-fold (0.86 log units) from the limit.
By their numbers in this assay, from the lowest: compound 3; then compound 2; then compound 1. At a limit, above all of these: compound 4.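

In this assay compound 4 stands at > 200000 nM and this is a limit of the assay, not a number. Pyridin-3-yl in place of 2-chloro-4-fluorophenyl gives an at least 12-fold higher number from compound 3 to compound 4 (1.10 log units; beyond the scatter) and so marks this position as far less tolerant of change than the only earlier step there suggested, which was a 2.0-fold lower number from compound 1 to compound 2 (0.31 log units; beyond the scatter) and modest. Among these compounds, this is also the first step at this position that starts from compound 3, the lowest number in the set, and it shows that an aromatic ring on the carbon with a double bond to nitrogen does not by itself keep the number low, although its true size stays unknown at the limit.

This one step cannot separate the departure of the chlorine and fluorine atoms from the entry of the pyridine ring nitrogen, and a plain phenyl group, a 4-fluorophenyl group or a 2-chlorophenyl group at this place would divide those two contributions. Also open, from the compounds shown here alone, is whether a phenyl ring carrying a methoxy group or an amine would hold the number near that of compound 3, and whether pyridin-3-yl would act the same way alongside the other aniline ring of compound 1 and compound 2.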